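This account rests on a few compounds, and the source may have more. Where it says the series, first, only, none or still open, it means among the compounds named here.

Three compounds share one core, each carrying a different ring on the amine nitrogen of the piperazine-like portion. Compound 1 `CC(C)CC1(CCCCN2CCN(c3cccc(Cl)c3)CC2)C(=O)Nc2ccccc21` was tested in a functional assay on the whole organism (strain NMRI) with Mus musculus as the target, with a stated time of 5 min; a lower number here means that less compound is needed, a higher number that more compound is needed for the effect. In this assay compound 1 reached only the limit of the measurement, giving > 10 mg/kg, which is a boundary rather than a number; this is summed up in the limit of > 10 mg/kg in this assay, at which 1 of the 2 values shown sits. Compound 2 `CCC1(CCCCN2CCN(c3cccc(OC)c3)CC2)C(=O)Nc2ccccc21` has no result in this assay, where compound 2 stands at "not determined" (no result reported), so no number is known for it. Compound 3 `CCC1(CCCCN2CCN(c3ccc(F)cc3)CC2)C(=O)Nc2ccccc21` differs from compound 2 in one place: 4-fluorophenyl in place of 3-methoxyphenyl on an amine nitrogen in a ring. Going by the values given here, no measured step between two compounds is known here, so the size of any change in this assay cannot be read off; the expectation is no step beyond the usual scatter. For compound 3 the value expected in this assay is 10 mg/kg, with a range from 3 mg/kg to 30 mg/kg, and it is estimated with the possibility that only a limit is reported.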

Compound 3, minimum effective dose: < 1 mg/kg
Compound 3: a limit, no number; the forecaster's own chance of this, stated with the estimate: 50%; middle value at least 10-fold (1.00 log units) away from the limit.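

Going by these compounds alone, no step from compound 2 to compound 3 can be read, since compound 2 has no number in this assay and compound 3 gives only a limit, < 1 mg/kg. The compounds shown leave open how far the change from 3-methoxyphenyl to 4-fluorophenyl alone shifts the dose needed.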